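Chain length on the aziridine-bearing sugar series

The source may report more compounds than this note shows. Statements on the series, on what has been measured and on what is new or still open speak of the compounds shown alone.

Measured so far:
compound 1 `CCCC1(CO[C@@H]2O[C@@H]3CO[C@H](c4ccccc4)O[C@@H]3[C@H](OCc3ccccc3)[C@H]2OCc2ccccc2)CN1S(=O)(=O)c1ccc(C)cc1` — 579000 nM
compound 2 `CCCCCCCCCC1(CO[C@@H]2O[C@@H]3CO[C@H](c4ccccc4)O[C@@H]3[C@H](OCc3ccccc3)[C@H]2OCc2ccccc2)CN1S(=O)(=O)c1ccc(C)cc1` — 154000 nM
compound 3 `Cc1ccc(S(=O)(=O)N2CC2(C)CO[C@@H]2O[C@@H]3CO[C@H](c4ccccc4)O[C@@H]3[C@H](O)[C@H]2O)cc1` — 154000 nM

In a functional assay on A549 cells (Homo sapiens) for cytotoxicity, read by MTT assay, with a stated time of 48 h (a higher number here means a weaker inhibitor, a lower number a stronger inhibitor), compound 2 stands level with compound 3 at the digits shown, and the two share the lowest number of the three; compound 1 sits furthest off, with a 3.8-fold lower number from compound 1 to compound 2 (0.58 log units; beyond the scatter) separating it from compound 2.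

Compound 4 `Cc1ccc(S(=O)(=O)N2CC2(C)CO[C@@H]2O[C@@H]3CO[C@H](c4ccccc4)O[C@@H]3[C@H](OCc3ccccc3)[C@H]2OCc2ccccc2)cc1` is not yet measured in this assay. Relative to compound 2 the change is hydrogen in place of octyl on a saturated chain carbon bound to a saturated ring carbon.

Within the data shown here, the one measured step that bears on this is the chain step from compound 1 to compound 2, a 3.8-fold lower number from compound 1 to compound 2 (0.58 log units; beyond the scatter), where lengthening the chain lowered the number. Compound 4 shortens the chain much further in the opposite direction, so a step of similar or somewhat larger size toward a higher number is expected, a 3.2-fold higher number from compound 2 to compound 4 (0.51 log units; beyond the scatter). Among the measured compounds shown here, compound 3 carries the same short chain with free hydroxyls and gives 154000 nM, but no step links it to compound 4, so it tempers the expectation without fixing it. Compound 4 is therefore estimated at 500000 nM, with a range from 150000 nM to 1500000 nM.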

Compound 4, half-maximal inhibitory concentration: 153000 nM
For compound 4 the middle estimate is 3.3-fold (0.51 log units) above the measured one, and the stated range covers the measured number.
By their numbers in this assay, from the lowest: compounds 4, 2 and 3 (each within the scatter of the next); then compound 1.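

In this assay the octyl group can go with no change in the number: a 1.0-fold lower number from compound 2 to compound 4 (0.00 log units; within the scatter). The step from the other chain gives a 3.8-fold lower number from compound 1 to compound 4 (0.58 log units; beyond the scatter), so the lowering seen earlier on lengthening the chain is not a steady trend at this position. Compound 1 goes against any such trend: its chain is longer than that of compound 4 and shorter than that of compound 2, yet its number lies beyond the scatter above both, while those two stay level. No measurement on hand accounts for this pattern.

Going by these compounds, whether a chain longer than nonyl, or an amine or carboxylic acid at the chain end, would move the number remains open. Also open, on these data alone, is whether the chain behaves the same way with the free hydroxyls of compound 3 on the core.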